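Aryl swap on the carbonyl carbon of the shared core

This account rests on a few compounds, and the source may have more. Where it says the series, first, only, none or still open, it means among the compounds named here.

Measured so far:
compound 1 `COc1cc(-c2cc(/C=C/C(=O)c3ccc(N)cc3)[nH]n2)cc(OC)c1OC`: 89%
compound 2 `COc1cc(-c2cc(/C=C/C(=O)c3ccc(Cl)c(Cl)c3)[nH]n2)cc(OC)c1OC`: 92%

In a functional assay on OVCAR-5 cells (Homo sapiens) for cytotoxicity, read by sulforhodamine B assay, with a stated time of 48 h, tested at 1 uM (on this read-out lower numbers stand for a stronger effect and higher numbers for a weaker effect at the one concentration tested), compound 2 stands highest of the two numbers, with compound 1 nearest. Among the compounds with values here, the only step measured so far is a number 3 percentage points higher from compound 1 to compound 2 (within the scatter).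

Compound 3 `COc1ccc(C(=O)/C=C/c2cc(-c3cc(OC)c(OC)c(OC)c3)n[nH]2)cc1OC` differs from compound 2 by 3,4-dimethoxyphenyl in place of 3,4-dichlorophenyl on a carbonyl carbon. Within the data shown here, the one step that bears on this change, a number 3 percentage points higher from compound 1 to compound 2 (within the scatter), also exchanged the aryl group on the carbonyl carbon and stayed within the scatter, so no step beyond the scatter is expected here either. Compound 3 is therefore expected to show a number 2 percentage points lower from compound 2 to compound 3 (within the scatter). In this assay compound 3 is estimated at 90%, with a range from 78% to 100%.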

Compound 3, a percentage reported as activity, at one concentration (the size of the read-out at that concentration, not a potency): 86%
The estimate for compound 3 lay 4 percentage points above the measured number; the range from low to high includes it.
By their numbers in this assay, from the lowest: compounds 3, 1 and 2 (each within the scatter of the next).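

In this assay, 3,4-dimethoxyphenyl on the carbonyl carbon, with 2 hydrogen-bond acceptors where 3,4-dichlorophenyl has 0, gives a number 6 percentage points lower from compound 2 to compound 3 (within the scatter) and a number 3 percentage points lower from compound 1 to compound 3 (within the scatter). The three aryl groups at this position thus stay within the scatter of one another, and none of the compounds stands apart. No measurement at hand bears on these numbers.

On these data alone, whether an aryl group carrying a carboxylic acid or a morpholine at this carbon would give a step beyond the scatter remains open. As far as these compounds go, the effect of replacing the trimethoxyphenyl group on the shared core also remains open.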